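The compounds below may be only part of what the source reports. "The series", "measured", "known", "first", "only" and "open" are said of these compounds alone.

Measured compounds:
compound 1 `CCCCCCCOc1ccc(CCC(N)(CO)CO)cc1` — in a functional assay on the whole organism (spleen, spleen) with Rattus norvegicus as the target (a lower number here means that less compound is needed, a higher number that more compound is needed for the effect), compound 1 gives 0.049 mg/kg
compound 2 `CCCCCCCOc1ccc(CC[C@](N)(CO)CCC)cc1` — in this assay compound 2 gives > 10 mg/kg, which is a limit of the assay and not a number

Compound 2 therefore stands at the limit of > 10 mg/kg in this assay, at which 1 of the 2 values shown sits; its true dose is known only to lie at or beyond that limit. Within the data shown here, the single measured step, an at least 200-fold higher number from compound 1 to compound 2 (2.30 log units; beyond the scatter), shows that replacing the second hydroxymethyl of the 1-amino-2-hydroxy-1-(hydroxymethyl)ethyl group by a plain chain end removes the effect within the tested range.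

Compound 3 `CCCCCCCOc1ccc(CCC(N)(CO)CCO)cc1` differs from compound 2 by a group of 7 heavy atoms (4 carbon, 1 nitrogen, 2 oxygen; no ring) in place of a group of 7 heavy atoms (5 carbon, 1 nitrogen, 1 oxygen; no ring), on a saturated chain carbon, two bonds along the chain from an aromatic carbon. The entering group carries 3 hydrogen-bond donors and 3 hydrogen-bond acceptors, where the leaving 1-amino-1-(hydroxymethyl)butyl carries 2 hydrogen-bond donors and 2 hydrogen-bond acceptors, so part of what compound 2 lost relative to compound 1 is put back. Among the measured compounds shown here, the step from compound 1 to compound 2 is the only one that bears on this; it was large and beyond the scatter, so a large step in the opposite direction is expected, though the entering group is not the one present in compound 1 and no measured pair covers it directly. In this assay compound 3 is expected near 0.3 mg/kg, within 0.05 mg/kg to 3 mg/kg, an expected step of an at least 33-fold lower number from compound 2 to compound 3 (1.52 log units; beyond the scatter).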

Compound 3, dose for 50% inhibition: 0.038 mg/kg
The estimate for compound 3 lay 7.9-fold (0.90 log units) above the measured number; measured number below the stated range.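

In this assay, the loss seen in compound 2 proves reversible at this position: the group with 4 carbon, 1 nitrogen and 2 oxygen atoms in place of 1-amino-1-(hydroxymethyl)butyl gives an at least 260-fold lower number from compound 2 to compound 3 (2.42 log units; beyond the scatter), so the effect depends on the hydroxy group that this change adds, not on the size of the group, which keeps its 7 heavy atoms. Compound 2 stands at a limit of the assay, so that step has a minimum size and no exact one: the limit of > 10 mg/kg in this assay, at which 1 of the 3 values shown sits. The two hydroxy-bearing arms also need not match, since hydroxymethyl in place of hydroxy on a saturated chain carbon, two bonds along the chain from an amine nitrogen, gives a 1.3-fold lower number from compound 1 to compound 3 (0.11 log units; within the scatter), which leaves the two compounds level in this assay.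

From the compounds shown here alone, how much further this arm can change remains open: a longer chain ending in hydroxy, a methoxy, an amine or a carboxylic acid at its end could each separate the need for a hydroxy from the need for a particular arm length. Compound 2 also has a defined stereocentre, whereas compound 3 has none drawn, so the contribution of the arrangement at that carbon remains unresolved.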